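A few compounds are considered here, and "the series" means these few. Any claim that something is new, unique, unknown or untested is made for them only; others in the source may bear on it.

Compound 3, with the structure `O=C1/C(=C/c2cccc(C(F)(F)F)c2)CCc2cc(O)ccc21`, gives 180 nM in a functional assay on RAW264.7 cells (Mus musculus) for inhibition (on this read-out lower numbers stand for stronger inhibition and higher numbers for weaker inhibition), the lowest of the three numbers recorded so far. Its nearest neighbour is compound 2, `O=C1/C(=C/c2cccc(F)c2)CCc2cc(O)ccc21`, which gives 1230 nM; the furthest is compound 1, `O=C1/C(=C/c2cccnc2)CCc2c(O)cccc21`, which gives 2950 nM and differs from the other two in more than one place, so its value only marks the far end of the range. For the measured compounds named here, the one single-point step in this set runs a 6.8-fold lower number from compound 2 to compound 3 (0.83 log units; beyond the scatter). Compound 4, `O=C1/C(=C/c2cccc(Cl)c2)CCc2cc(O)ccc21`, departs from compound 3 by chloro in place of trifluoromethyl on an aromatic carbon, on an aromatic carbon of a six-membered aromatic ring of carbon only. Chloro is neither the fluoro of compound 2 nor the trifluoromethyl of compound 3, so the step from compound 2 to compound 3 is the only one bearing on it, and it is expected that compound 4 lands between those two, nearer compound 3, meaning a modest rise of a 2.5-fold higher number from compound 3 to compound 4 (0.40 log units; beyond the scatter) that may or may not clear the scatter. Compound 4 is therefore estimated at 450 nM, within a range from 180 nM to 1200 nM.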

Compound 4, half-maximal inhibitory concentration: 1750 nM
Estimate against measurement, compound 4: 3.9-fold (0.59 log units) below, outside the stated range (above it).
By their numbers in this assay, from the lowest: compound 3; then compounds 2, 4 and 1 (each within the scatter of the next, the first and the last beyond it).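

The result shows that the low number at this position in this assay does not carry over to every halogen-bearing group: chloro in place of trifluoromethyl gives a clear loss (a 9.7-fold higher number from compound 3 to compound 4 (0.99 log units; beyond the scatter)). Chloro and fluoro cannot be told apart here (a 1.4-fold higher number from compound 2 to compound 4 (0.15 log units; within the scatter)), so the three groups do not form a graded series, and among them only trifluoromethyl stands apart. The earlier step had shown a gain on going to trifluoromethyl, but not that chloro would fall with fluoro rather than with trifluoromethyl, and no measurement here accounts for this split.

The compounds shown leave open whether a methyl, a methoxy or a nitrile on this carbon would read with trifluoromethyl or with the two halogens. They also leave open whether trifluoromethyl would give a similar number on another carbon of this ring.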